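A few compounds are considered here, and "the series" means these few. Any claim that something is new, unique, unknown or untested is made for them only; others in the source may bear on it.

Measured compounds:
compound 3 `COc1ncc(-c2ccn3nc(NC(C)=O)nc3c2)cc1NS(=O)(=O)c1ccc(Cl)cc1` — 1240 nM
compound 1 `COc1ncc(-c2ccc3nc(NC(=O)C4CC4)nn3c2)cc1NS(=O)(=O)c1ccc(F)cc1` — 2590 nM
compound 2 `CCOC(=O)CNc1nc2ccc(-c3cnc(OC)c(NS(=O)(=O)c4ccc(F)cc4)c3)cn2n1` — 4410 nM

In a functional assay on MCF7 cells (Homo sapiens) for antiproliferative activity, read by MTT assay, with a stated time of 48 h (on this read-out higher numbers stand for weaker inhibition and lower numbers for stronger inhibition), compound 3 gives the lowest number of the three, with compound 1 at 2590 nM and compound 2 at 4410 nM both higher. Compound 4 `COc1ncc(-c2ccn3nc(NC(C)=O)nc3c2)cc1NS(=O)(=O)c1ccc(C)cc1` differs from compound 3 in one place: methyl in place of chloro on an aromatic carbon. Among the measured compounds shown here, the only measured step, a 1.7-fold higher number from compound 1 to compound 2 (0.23 log units; within the scatter), concerns the group on the ring nitrogen at the other end of the shared core and has no bearing on the sulfonyl aryl; it shows that a change at that end left the number within the scatter. For the measured compounds named here, no measured pair speaks to the chloro-to-methyl exchange itself. For compound 4 a step of only modest size is therefore expected, a 1.5-fold higher number from compound 3 to compound 4 (0.16 log units; within the scatter), with a slight lean toward a higher number. Compound 4 is expected to give about 1800 nM in this assay, within a range of 700 nM to 4500 nM.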

Compound 4, half-maximal inhibitory concentration: 1360 nM
For compound 4 the middle estimate is 1.3-fold (0.12 log units) above the measured one, and the stated range covers the measured number.
By their numbers in this assay, from the lowest: compounds 3, 4, 1 and 2 (each within the scatter of the next, the first and the last beyond it).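

Among the compounds shown here, the step on the aromatic carbon para to a large group is the first measured change at the sulfonyl aryl: in this assay, going from 4-chlorophenyl to 4-methylphenyl gives a 1.1-fold higher number from compound 3 to compound 4 (0.04 log units; within the scatter). Chloro and methyl therefore cannot be told apart at this position on the core shared by these two compounds, and the exchange leaves the number within the scatter. No measurement shown here accounts for this result.

On these data alone, whether an amine, a carboxylic acid or a longer chain in this place would also leave the number within the scatter stays open. Also open, as far as these compounds go, is whether the same exchange would read alike on the core of compound 1, which differs from compound 3 in more than one place.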